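The source may hold more compounds than are shown below. What is called first, only, known or untested is meant among the compounds shown, and "the series" means these compounds.

Measured in a functional assay on Ehrlich cells (Mus musculus) for cytotoxicity, read by trypan blue exclusion, with a stated time of 2 h, tested at 25 ug/mL; a lower number here means a weaker effect, a higher number a stronger effect of the compound at the concentration tested:
compound 1 `N#CC1=C(N)N(c2ccc(S(N)(=O)=O)cc2)C2=C(CCCC2)C1c1ccccc1` — 10%
compound 2 `Cc1ccc(C2C(C#N)=C(N)N(c3ccc(S(N)(=O)=O)cc3)C3=C2CCCC3)cc1` — 30%
compound 3 `N#CC1=C(N)N(c2ccc(S(N)(=O)=O)cc2)C2=C(CCCC2)C1c1cccc([N+](=O)[O-])c1` — 1%

Compound 3 holds the lowest of the three numbers: the step of a number 29 percentage points lower from compound 2 to compound 3 (beyond the scatter) lies beyond the scatter, whereas the step of a number 9 percentage points lower from compound 1 to compound 3 (within the scatter) does not, so compound 3 and compound 1 cannot be ordered. Compound 4 `N#CC1=C(N)N(c2ccc(S(N)(=O)=O)cc2)C2=C(CCCC2)C1c1ccc(Cl)cc1Cl` differs from compound 3 by 2,4-dichlorophenyl in place of 3-nitrophenyl on a saturated ring carbon. Going by the values given here, only the step of a number 29 percentage points lower from compound 2 to compound 3 (beyond the scatter) bears directly on an exchange at this saturated ring carbon, and it was modest; no measured step involves chlorine on the aryl group. A rise is therefore expected for compound 4, of about a number 17 percentage points higher from compound 3 to compound 4 (beyond the scatter), modest at most. In this assay compound 4 is estimated at 18%, within 3% to 40%.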

Compound 4, a percentage reported as activity, at one concentration (the size of the read-out at that concentration, not a potency): 50%
Estimate against measurement, compound 4: 32 percentage points below; the measured number lies above the stated range.
By their numbers in this assay, from the lowest: compounds 3 and 1 (each within the scatter of the next); then compound 2; then compound 4.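

In this assay, going by these compounds alone, the aryl group on the saturated ring carbon, changed alone, moves the read-out further than the earlier compounds showed, with a number 49 percentage points higher from compound 3 to compound 4 (beyond the scatter) and a number 40 percentage points higher from compound 1 to compound 4 (beyond the scatter) as large steps. 2,4-Dichlorophenyl also goes beyond 4-methylphenyl, with a number 20 percentage points higher from compound 2 to compound 4 (beyond the scatter) as a modest step, and compound 4 now holds the highest number of the four. Nothing available bears on the cause of these steps.

Still open, on these data alone, is how 4-chlorophenyl or 2-chlorophenyl would compare with 2,4-dichlorophenyl, and where a methoxy group or a carboxylic acid on the aryl ring would fall.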